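A New Aromatic Group on Compound 3

The source may hold more compounds than are shown below. What is called first, only, known or untested is meant among the compounds shown, and "the series" means these compounds.

In a functional assay on DU-145 cells (Homo sapiens) for inhibition, read by trypan blue exclusion, with a stated time of 96 h (a lower number here means a stronger inhibitor of growth, a higher number a weaker inhibitor of growth), compound 1 `O=C(/C(=C\c1ccc(Cl)c([N+](=O)[O-])c1)S(=O)(=O)c1ccc(Br)cc1)c1ccc(Br)cc1` gives 10000 nM while compound 3 `COc1ccc(/C=C(\C(=O)c2ccc(Br)cc2)S(=O)(=O)c2ccc(Br)cc2)c(OC)c1` gives 8000 nM as its value. For the measured compounds named here, these two numbers lie within the scatter of each other, so compound 3 stands level with the only other true number available. Compound 2 `Nc1c(Br)cc(Br)cc1/C=C(/Sc1ccc(Br)cc1)C(=O)c1ccc(Br)cc1` gives > 100000 nM as a limit of the assay and not as a number.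

The next structure is compound 4 `Nc1c(Br)cc(Br)cc1/C=C(\C(=O)c1ccc(Br)cc1)S(=O)(=O)c1ccc(Br)cc1` and the change that leads to it from compound 3 is 2-amino-3,5-dibromophenyl in place of 2,4-dimethoxyphenyl on a double-bonded chain carbon bound to a double-bonded chain carbon in one place. It puts 2-amino-3,5-dibromophenyl in place of 2,4-dimethoxyphenyl on a double-bonded chain carbon bound to a double-bonded chain carbon.

Going by the values given here, the one measured step at this place is a 1.3-fold lower number from compound 1 to compound 3 (0.10 log units; within the scatter) and it stayed within the scatter. No step beyond the scatter is therefore expected in this assay and the estimated move is a 1.3-fold higher number from compound 3 to compound 4 (0.10 log units; within the scatter) at its middle. This expectation rests on a single step. The entering group also stands on compound 2, which yielded no number, so the range has to stay wide. For compound 4 the estimated value is 10000 nM with an expected range from 2000 nM to 50000 nM in this measurement.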

Compound 4, concentration for 50% growth inhibition: 25000 nM
For compound 4 the middle estimate is 2.5-fold (0.40 log units) below the measured one; measured number inside the range.
By their numbers in this assay, from the lowest: compounds 3 and 1 (each within the scatter of the next); then compound 4. At a limit, above all of these: compound 2.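

In this assay, this place on a double-bonded chain carbon bound to a double-bonded chain carbon now shows that the choice of aromatic group can matter, with 2-amino-3,5-dibromophenyl giving steps beyond the scatter against both earlier groups (a 3.1-fold higher number from compound 3 to compound 4 (0.49 log units; beyond the scatter) and a 2.5-fold higher number from compound 1 to compound 4 (0.40 log units; beyond the scatter)), whereas the earlier swap here stayed within it. For the compounds shown here, the same compound also gives the first reading at a second place, where (4-bromophenyl)sulfonyl stands in place of (4-bromophenyl)sulfanyl while the 2-amino-3,5-dibromophenyl group stays fixed (an at least 4.0-fold lower number from compound 2 to compound 4 (0.60 log units; beyond the scatter)). The true size of that step cannot be told, because the value of compound 2 is a limit of the assay and not a number: the limit of > 100000 nM in this assay, at which 1 of the 4 values shown sits.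

The entering group differs from the one it replaces in several ways at once, so the compounds shown cannot say whether the amine or the two bromines go with the higher number; a plain 2-aminophenyl group would separate the two. On these data alone, it also stays open whether the change from sulfonyl to sulfanyl would cost as much with 2,4-dimethoxyphenyl in place.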